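The source may report more compounds than this note shows. Statements on the series, on what has been measured and on what is new or still open speak of the compounds shown alone.

Working notes on the series. The read-out is a functional assay on WI-38 VA13 cells (Homo sapiens) for cytotoxicity; on this read-out lower numbers stand for an effect already at smaller amounts and higher numbers for an effect only at larger amounts of compound. Three members of the shared core carry a ketone at the same position. Compound 2 `CCC(=O)c1sc2nc(-c3cccs3)ccc2c1N` bears an ethyl ketone and an amino group; in this assay compound 2 gives 0.89 ug/mL. Compound 3 `Nc1c(C(=O)c2cccc([N+](=O)[O-])c2)sc2nc(-c3cccs3)ccc12` carries a nitrophenyl ketone with the same amino group, and in this assay compound 3 gives 0.15 ug/mL. Compound 1 `CN(C)c1c(C(=O)c2ccccc2)sc2nc(-c3cccs3)ccc12`, with a dimethylamino group in place of the amine and a plain phenyl ketone, reaches only a limit in this assay, where compound 1 gives > 4 ug/mL; this is the limit of > 4 ug/mL in this assay, at which 1 of the 3 values shown sits, not a number.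

Among the two numbers, compound 2 holds the higher one, and the gap to compound 3 lies beyond the scatter.

Compound 4 `Nc1c(C(=O)c2ccc(F)cc2)sc2nc(-c3cccs3)ccc12` has not yet been measured. Its difference from compound 2 is 4-fluorophenyl in place of ethyl on a carbonyl carbon. The amino group is kept, so the comparison with compound 3 rests on an aryl ketone against an alkyl ketone.

In this assay compound 4 is expected to give roughly 0.3 ug/mL, with a plausible range of 0.1 ug/mL to 0.9 ug/mL. The estimated step of a 3.0-fold lower number from compound 2 to compound 4 (0.47 log units; beyond the scatter) would thus be a move toward a lower number, beyond the scatter, though smaller than the gap between compound 2 and compound 3.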

Compound 4, half-maximal effective concentration: 1.8 ug/mL
Compound 4: middle estimate off by 6.0-fold (0.78 log units), on the low side, outside the stated range (above it).
By their numbers in this assay, from the lowest: compound 3; then compound 2; then compound 4. At a limit, above all of these: compound 1.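

Putting 4-fluorophenyl in place of ethyl on a carbonyl carbon gives, in this assay, a 2.0-fold higher number from compound 2 to compound 4 (0.31 log units; beyond the scatter), so at this position an aromatic ring does not by itself bring a lower number. With the amino group kept in both, compound 3, which carries the nitrophenyl ketone, gives 0.15 ug/mL, whereas compound 4 gives 1.8 ug/mL; the two aryl ketones thus fall on opposite sides of the ethyl ketone of compound 2, and what is attached to the phenyl ring matters at least as much here as the swap from alkyl to aryl. Nothing measured in the series accounts for this step.

Going by these compounds, it remains open how the number responds to other groups at this position, such as a carboxylic acid on the phenyl ring or a butyl chain on the carbonyl carbon in place of ethyl. The contribution of the amino group alone also stays unresolved, as compound 1 differs from each of the other compounds in more than one place.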